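A Bromophenyl Amide Replaces a Cyclopentyl Amide

The source may report more compounds than this note shows. Statements on the series, on what has been measured and on what is new or still open speak of the compounds shown alone.

Of the compounds shown here, two have been measured in a toxicity assay on THP-1 cells (Homo sapiens) for inhibition (on this read-out lower numbers stand for higher toxicity in this test and higher numbers for lower toxicity in this test), so far. Compound 1 `COc1ccc(CNC(=O)NC(=O)c2ccc(F)cc2)cc1` reached only a limit in this assay, giving > 50000 nM. Compound 2 `COc1ccc(-c2cnc(NC(=O)C3CCCC3)n2C)cc1` likewise reached only a limit, giving > 100000 nM in this assay. Both values are therefore bounds rather than numbers: the limit of > 100000 nM in this assay, at which 1 of the 2 values shown sits, and (the limit of > 50000 nM in this assay, at which 1 of the 2 values shown sits). On the numbers shown, compound 2 stands at the higher of the two limits, with no measured step connecting it to compound 1.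

Compound 3 `COc1ccc(-c2cnc(NC(=O)c3cccc(Br)c3)n2C)cc1` has not yet been measured. It differs from compound 2 in one place: 3-bromophenyl in place of cyclopentyl on a carbonyl carbon. Going by the values given here, with no measured step available, the expected change from compound 2 to compound 3 in this assay is small, perhaps a modest move toward higher toxicity, but likely not clearly beyond the scatter, i.e. an at least 1.4-fold lower number from compound 2 to compound 3 (0.15 log units; that floor lies within the scatter). Compound 3 is estimated at 70000 nM, within a range of 20000 nM to 200000 nM.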

Compound 3, half-maximal cytotoxic concentration: > 100000 nM
Compound 3 was reported as a limit (the forecaster's own chance of this, stated with the estimate: 55%); middle value at least 1.4-fold (0.15 log units) away from the limit.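

Going by these compounds alone, compound 2 and compound 3 are both reported only as limits, so no step from cyclopentyl to 3-bromophenyl can be read: the limit of > 100000 nM in this assay, at which 2 of the 3 values shown sit. The compounds shown leave open whether this exchange changes the half-maximal cytotoxic concentration at all.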